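Swapping the para substituent: from difluoromethoxy to an amidine

The compounds below may be only part of what the source reports. "The series", "measured", "known", "first", "only" and "open" are said of these compounds alone.

Measured compounds:
Compound 1, `Cn1nc2c(=O)n(CC3(O)CCN(Cc4ccc(-c5ccco5)cc4Cl)CC3)cnc2c1-c1ccc(C(F)(F)F)cc1`: 530 nM
Compound 2, `Cn1nc2c(=O)n(CC3(O)CCN(Cc4ccc(-c5ccco5)cc4Cl)CC3)cnc2c1-c1ccc(OC(F)F)cc1`: 179 nM

In an assay on isolated protein for inhibition of ubiquitin carboxyl-terminal hydrolase 7 (Homo sapiens), with stated times of 30 min and 2 h (on this read-out higher numbers stand for weaker inhibition and lower numbers for stronger inhibition), compound 1 gives 530 nM, and compound 2 gives 179 nM. Within the data shown here, the one measured step, a 3.0-fold lower number from compound 1 to compound 2 (0.47 log units; beyond the scatter), is modest yet beyond the scatter. Among the measured compounds shown here, compound 2 therefore stands with the lowest number of the two, and compound 1 is its only neighbour.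

Compound 3, `Cn1nc2c(=O)n(CC3(O)CCN(Cc4ccc(-c5ccco5)cc4Cl)CC3)cnc2c1-c1ccc(C(=N)N)cc1`, has not been measured. It differs from compound 2 by a group of 3 heavy atoms (1 carbon, 2 nitrogen; no ring) in place of a group of 4 heavy atoms (1 carbon, 1 oxygen, 2 fluorine; no ring), on an aromatic carbon. The group that enters carries two hydrogen-bond donors and one acceptor and sits on the same aromatic carbon that held the difluoromethoxy.

For the measured compounds named here, no measured step exchanges a fluorinated group for a nitrogen-bearing one; the step from compound 1 to compound 2 only shows that a change at this position can shift the number by a modest amount. An expectation for compound 3 thus rests on a single analogy and is uncertain in direction. A step back toward a somewhat higher number is expected, a 2.5-fold higher number from compound 2 to compound 3 (0.40 log units; beyond the scatter), with a wide range. The estimate for compound 3 is 450 nM, between 120 nM and 2000 nM.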

Compound 3, half-maximal inhibitory concentration: 87.5 nM
Compound 3: middle estimate off by 5.1-fold (0.71 log units), on the high side, and the stated range ends above it.
By their numbers in this assay, from the lowest: compound 3; then compound 2; then compound 1.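

In this assay, the aromatic carbon para to a large group proves open to more than fluorinated groups: an amidine, which carries hydrogen-bond donors and no fluorine, gives a 2.0-fold lower number from compound 2 to compound 3 (0.31 log units; beyond the scatter), and the comparison with trifluoromethyl gives a 6.1-fold lower number from compound 1 to compound 3 (0.78 log units; beyond the scatter). Compounds 1 and 2 had shown only that one fluorinated group could be exchanged for another at this place, whereas compound 3 extends the series to a nitrogen-bearing group and has the lowest number of the three, with both of its steps beyond the scatter. The data show this shift but include no measurement that accounts for it.

From the compounds shown here alone, what remains open is whether other nitrogen-bearing or charged-capable groups at this aromatic carbon, such as an aminomethyl group, a primary amide or a carboxylic acid, would continue the trend or reverse it. Going by these compounds, it is also open whether the gain from the amidine would carry over if the furan-bearing benzyl part of the shared structure were changed, as all three compounds have that part in common.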